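This account rests on a few compounds, and the source may have more. Where it says the series, first, only, none or still open, it means among the compounds named here.

Measured compounds:
compound 1, `Cn1c(-c2cccnc2)nc2ccc(F)cc21`: 677 nM
compound 2, `c1cncc(-c2nc3ccccc3n2C2CC2)c1`: > 8330 nM

Compound 2 is the starting point of this step. In an assay on V79 cells for inhibition of cytochrome P450 11B1, mitochondrial (Homo sapiens), read by HTRF, with a stated time of 1 h (a higher number here means a weaker inhibitor, a lower number a stronger inhibitor), compound 2 gives > 8330 nM, which is a limit of the assay rather than a number. This is noted in the limit of > 8330 nM in this assay, at which 1 of the 2 values shown sits. For the measured compounds named here, the only other measured compound, compound 1, carries a fluoro on its core and a methyl in place of the cyclopropyl, and in this assay compound 1 gives 677 nM; with two differences between them, the two values can only be set side by side.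

The step to compound 3, `Fc1ccc2nc(-c3cccnc3)n(C3CC3)c2c1`, is fluoro in place of hydrogen on an aromatic carbon. Going by the values given here, no measured pair shows what this change alone does. With compound 2 sitting at a limit, only a modest gain toward a measurable value seems reasonable, so compound 3 is expected to give 5000 nM, in the range 1500 nM to 20000 nM, a step of an at least 1.6-fold lower number from compound 2 to compound 3 (0.22 log units; that floor lies within the scatter) that is itself an estimate.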

Compound 3, half-maximal inhibitory concentration: 401 nM
Beside the measured number, compound 3's estimate is 12-fold (1.10 log units) above it; measured number below the stated range.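

Fluoro in place of hydrogen on an aromatic carbon now has a reading of its own in this assay, and this single change gives an at least 20-fold lower number from compound 2 to compound 3 (1.31 log units; beyond the scatter). Compound 2 stands at > 8330 nM, which is a limit of the assay and not a number. With the fluoro in place, cyclopropyl in place of methyl on an aromatic nitrogen gives a 1.7-fold lower number from compound 1 to compound 3 (0.23 log units; within the scatter), so the two groups on that nitrogen cannot be told apart here.

From the compounds shown here alone, only hydrogen and fluoro appear at this aromatic carbon, so it remains open how chloro, a methoxy group or an amine would behave there, or fluoro on another carbon of the same ring. Going by these compounds, on the nitrogen, an ethyl group or a longer chain also remains open.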